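Adding a Fluoro to the 4-Fluorophenyl of Compound 1

This account rests on a few compounds, and the source may have more. Where it says the series, first, only, none or still open, it means among the compounds named here.

Compound 1, `O=C(c1ccc(F)cc1)N1CCc2nc(COc3cccc(F)c3)oc2C1`, in a functional assay on HEK293 cells for positive allosteric modulation of metabotropic glutamate receptor 5 (Homo sapiens), read by calcium flux (a lower number here means a smaller maximal response, a higher number a larger maximal response), gives 78%.
Compound 2, `O=C(c1ccc(F)cc1)N1CCc2nc(COc3ccccn3)oc2C1`, gives 75%.
Compound 3, `O=C(c1ccc(F)cc1)N1CCc2nc(COc3ccncc3)oc2C1`, gives 71%.

Compound 1 holds the highest of the three numbers, yet every gap is small: a number 3 percentage points lower from compound 1 to compound 2 (within the scatter), a number 7 percentage points lower from compound 1 to compound 3 (within the scatter), and a number 4 percentage points lower from compound 2 to compound 3 (within the scatter). Compound 4, `O=C(c1ccc(F)c(F)c1)N1CCc2nc(COc3cccc(F)c3)oc2C1`, differs from compound 1 by fluoro in place of hydrogen on an aromatic carbon. Going by the values given here, none of the measured steps touches this part of the molecule; all three exchange the group on the oxygen on the saturated carbon, and all stay within the scatter. So no measured step bears directly on the change, and the expected step, no change at the digits printed from compound 1 to compound 4 (within the scatter), is none beyond the scatter. Compound 4 is therefore estimated to give about 78%, expected between 65% and 91%.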

Compound 4, largest response reached (reported as percent of maximum), in percent of the reference or control that the assay uses: 71%
Compound 4: middle estimate off by 7 percentage points, on the high side, and the stated range covers the measured number.
By their numbers in this assay, from the lowest: compounds 3, 4, 2 and 1 (each within the scatter of the next).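

In this assay, going by these compounds alone, the change from 4-fluorophenyl to 3,4-difluorophenyl gives a number 7 percentage points lower from compound 1 to compound 4 (within the scatter) and is the first measured step on this ring. The shared core therefore accepts a second fluoro here with no shift beyond the scatter, as the earlier exchanges on the oxygen also showed for their part of the molecule. No measurement shown offers an explanation for this step.

As far as these compounds go, it remains open how a larger group at this place, such as methoxy or an amine, would behave. Also open, from the compounds shown here alone, is whether the same fluoro would give a similar step on compound 2 or compound 3.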